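A few compounds are considered here, and "the series" means these few. Any claim that something is new, unique, unknown or untested is made for them only; others in the source may bear on it.

The measured compounds:
compound 1 `C=CC(=O)Nc1cccc(NC(=O)CSc2nc(Nc3ccccc3Br)c3ccccc3n2)c1` gave 15200 nM
compound 2 `C=CC(=O)Nc1cccc(NC(=O)CSc2nc(Nc3cccc(Br)c3)c3ccccc3n2)c1` gave 19400 nM
compound 3 `C=CC(=O)Nc1cccc(NC(=O)CSc2nc(Nc3cccc([N+](=O)[O-])c3)c3ccccc3n2)c1` gave > 50000 nM

All three share one core and were tested in a functional assay on MDA-MB-231 cells (Homo sapiens) for inhibition, read by MTT assay, with a stated time of 72 h; on this read-out higher numbers stand for weaker inhibition and lower numbers for stronger inhibition. Compound 1 and compound 2 differ only in where the bromine sits on the phenyl attached to the amine nitrogen, and the step of a 1.3-fold higher number from compound 1 to compound 2 (0.11 log units; within the scatter) lies within the scatter, so the two cannot be ranked. On these data alone, for compound 3 the assay gave only a limit, (the limit of > 50000 nM in this assay, at which 1 of the 3 values shown sits), not a number, so its true value is unknown. The step of an at least 2.5-fold higher number from compound 2 to compound 3 (0.41 log units; beyond the scatter) and the step of an at least 3.2-fold higher number from compound 1 to compound 3 (0.51 log units; beyond the scatter) each raised the number beyond the scatter, which places compound 3 at the weak end of what has been seen so far.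

Compound 4 `C=CC(=O)Nc1cccc(NC(=O)CSc2nc(Nc3cccc(C)c3)c3ccccc3n2)c1` has not been measured. It differs from compound 3 by methyl in place of nitro on an aromatic carbon. Among the compounds with values here, the two steps that bear on this, the one from compound 2 and the one from compound 1 to compound 3, both ended at the nitro compound with the higher number. Taking the nitro group away is expected to bring the number back down, by a modest amount at least. Compound 4 is therefore estimated at 20000 nM, with a range from 7000 nM to 60000 nM. The expected step is an at least 2.5-fold lower number from compound 3 to compound 4 (0.39 log units; beyond the scatter).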

Compound 4, half-maximal inhibitory concentration: 16800 nM
The estimate for compound 4 lay 1.2-fold (0.08 log units) above the measured number; low and high end bracket the measured number.
By their numbers in this assay, from the lowest: compounds 1, 4 and 2 (each within the scatter of the next). At a limit, above all of these: compound 3.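

In this assay, the change from nitro to methyl on the same ring carbon gives an at least 2.9-fold lower number from compound 3 to compound 4 (0.47 log units; beyond the scatter), so the high number of compound 3 does not extend to every group at this place on the phenyl ring. On these data alone, the true size of that step stays unknown, as compound 3 stands at a limit and not at a number: the limit of > 50000 nM in this assay, at which 1 of the 4 values shown sits. Methyl also cannot be told apart from either bromine compound, with a 1.2-fold lower number from compound 2 to compound 4 (0.06 log units; within the scatter) and a 1.1-fold higher number from compound 1 to compound 4 (0.04 log units; within the scatter) both within the scatter, so among the four compounds only the nitro compound stands apart.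

These four compounds do not show why nitro differs from methyl and bromo, nor whether this reflects a general trend, as a single nitro compound offers no basis for one. As far as these compounds go, it also remains open how an amine, a methoxy group or a carboxylic acid on the same ring carbon would read, and whether any of them could bring the number clearly below those of compound 1, compound 2 and compound 4.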